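Propylamino for Methyl on a Core Without Measured Cytotoxicity

The source may hold more compounds than are shown below. What is called first, only, known or untested is meant among the compounds shown, and "the series" means these compounds.

Three compounds have been measured in a functional assay on G-361 cells (Homo sapiens) for cytotoxicity, read by sulforhodamine B assay; a lower number here means that less compound is tolerated, a higher number that more compound is tolerated:
compound 1 `CCCNc1nc(C)nc2c1cnn2-c1ccccc1` gives > 100000 nM, a limit of the assay.
compound 2 `Cc1nc(NCc2ccco2)c2cnn(-c3ccccc3)c2n1` gives > 100000 nM, again a limit of the assay.
compound 3 `Cc1nc(NCc2ccccc2)c2cnn(-c3ccccc3)c2n1` gives > 100000 nM, also a limit of the assay.

Compound 1 therefore stands at the limit of > 100000 nM in this assay, at which 3 of the 3 values shown sit, and nothing places it above or below its two relatives. The steps from compound 1 to compound 2 a step that the two limits leave unreadable from compound 1 to compound 2, from compound 1 to compound 3 a step that the two limits leave unreadable from compound 1 to compound 3 and from compound 2 to compound 3 a step that the two limits leave unreadable from compound 2 to compound 3 all vary the group on the saturated chain carbon bound to the ring nitrogen and remain unreadable.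

Compound 4 `CCCNc1nc(NCCC)c2cnn(-c3ccccc3)c2n1` differs from compound 1 by propylamino in place of methyl on an aromatic carbon. Among the measured compounds shown here, no measured step touches this position, so no measured step bears directly on it. Since compound 1 sits at the limit of > 100000 nM in this assay, at which 3 of the 3 values shown sit, the expectation for compound 4 is that it too stays at the limit, an estimated 100000 nM with a range from 30000 nM to 300000 nM. That estimate means an expected step from compound 1 to compound 4 of a number no higher from compound 1 to compound 4 (the limit leaves the size open).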

Compound 4, concentration lethal to 50% of the cells: > 100000 nM
Compound 4: only a limit was reported (the forecaster's own chance of this, stated with the estimate: 80%); the middle value lies on the limit itself.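

Compared with compound 1, compound 4 gives > 100000 nM in this assay, a limit of the assay, so no new step can be read: the limit of > 100000 nM in this assay, at which 4 of the 4 values shown sit.

The compounds shown leave open how far each true value lies from that limit, and whether any of these changes affects cytotoxicity at all.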